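Working notes: compound 3 to compound 4

The source may hold more compounds than are shown below. What is called first, only, known or untested is meant among the compounds shown, and "the series" means these compounds.

Values in a functional assay on NCI-H520 cells (Homo sapiens) for cytotoxicity; a lower number here means a stronger inhibitor of growth, a higher number a weaker inhibitor of growth:
- Compound 1 `CSc1ccc(C2=C(c3ccc(F)c(F)c3)C(=O)N3CCCC3C2)cc1`: 200 nM
- Compound 2 `CSc1ccc(C2=C(c3ccc(F)c(C)c3)C(=O)N3CCCC3C2)cc1`: 500 nM
- Compound 3 `COc1ccc(C2=C(c3ccc(SC)cc3)CC3CCCN3C2=O)cc1`: 800 nM

The standing of compound 3 rests on two gaps: a 4.0-fold higher number from compound 1 to compound 3 (0.60 log units; beyond the scatter) lies beyond the scatter, while a 1.6-fold higher number from compound 2 to compound 3 (0.20 log units; within the scatter) lies within it.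

Compound 4 `CSc1ccc(C2=C(c3ccc(O)cc3)C(=O)N3CCCC3C2)cc1` differs by one change: hydrogen in place of methyl on an oxygen on an aromatic ring, methoxy to hydroxy. Among the compounds with values here, no measured step makes this exact change. The closest small swap, a 2.5-fold higher number from compound 1 to compound 2 (0.40 log units; beyond the scatter), is a methyl in place of fluoro on an aromatic carbon and stayed modest. No step beyond the scatter is therefore expected in this assay. The expected step is a 1.3-fold higher number from compound 3 to compound 4 (0.10 log units; within the scatter). Compound 4 is estimated at 1000 nM, with an expected range of 300 nM to 3500 nM.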

Compound 4, concentration for 50% growth inhibition: > 100000 nM
Compound 4 was reported as a limit; the forecaster's own chance of this, stated with the estimate: 5%; at least 100-fold (2.00 log units) between middle value and limit.
By their numbers in this assay, from the lowest: compound 1; then compounds 2 and 3 (each within the scatter of the next). At a limit, above all of these: compound 4.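

In this assay compound 4 gives a limit, not a number: the limit of > 100000 nM in this assay, at which 1 of the 4 values shown sits.
Hydroxy in place of methoxy on the aromatic ring gives an at least 120-fold higher number from compound 3 to compound 4 (2.09 log units; beyond the scatter) and so outweighs the earlier swaps of this aryl group, which stayed modest or within the scatter. The wider comparisons an at least 200-fold higher number from compound 2 to compound 4 (2.30 log units; beyond the scatter) and an at least 500-fold higher number from compound 1 to compound 4 (2.69 log units; beyond the scatter) agree, so removing one methyl from that oxygen separates measurable growth inhibition from the limit.

The compounds shown leave open why the hydroxy reaches this limit. On these data alone, whether an amine or an ethoxy in the same place would stay near compound 3 or go the way of compound 4 also remains open.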